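Quinoxalinylmethyl piperazine variant of the benzimidazole series

The compounds below may be only part of what the source reports. "The series", "measured", "known", "first", "only" and "open" are said of these compounds alone.

Two measured compounds share the core seen in compound 1 `Cn1c(=O)c(=O)[nH]c2ccc(CN3CCN(c4cccc5[nH]c(-c6ccc(C(C)(C)C)cc6)nc45)CC3)cc21`, which in a functional assay for antagonist activity at Gonadotropin-releasing hormone receptor (Homo sapiens) (on this read-out lower numbers stand for stronger inhibition and higher numbers for weaker inhibition), gives 7.4 nM. For the measured compounds named here, compound 2 `CC(C)(C)c1ccc(-c2nc3c(N4CCN(Cc5ccc6ncccc6c5)CC4)cccc3[nH]2)cc1` gives 64 nM in this assay, the higher of the two numbers on record and beyond the scatter from compound 1; the two differ in more than one place, so no single step is drawn between them.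

Compound 3 `CC(C)(C)c1ccc(-c2nc3c(N4CCN(Cc5cccc6nccnc56)CC4)cccc3[nH]2)cc1` differs from compound 2 in one place only: quinoxalin-5-yl in place of quinolin-6-yl on a saturated chain carbon bound to an amine nitrogen in a ring. Going by the values given here, no measured pair shows this change, so nothing on record tells its direction or size. With only the higher number of compound 2 as the reference point, the step from compound 2 to compound 3 is expected to be small, at or near the scatter, with no clear direction, a 1.3-fold lower number from compound 2 to compound 3 (0.11 log units; within the scatter). Compound 3 in this assay is therefore estimated at 50 nM, with a range from 15 nM to 200 nM.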

Compound 3, half-maximal inhibitory concentration: 400 nM
Compound 3: the middle estimate sits 8.0-fold (0.90 log units) below what was measured; measured number outside the range, above it.
By their numbers in this assay, from the lowest: compound 1; then compound 2; then compound 3.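

Quinoxalin-5-yl and quinolin-6-yl are not interchangeable on a saturated chain carbon bound to an amine nitrogen in a ring: in this assay the replacement gives a 6.3-fold higher number from compound 2 to compound 3 (0.80 log units; beyond the scatter), so this position does respond to the choice of aromatic group. The response appears even though both groups have the same number of heavy atoms and neither has a hydrogen-bond donor, so heavy-atom count alone does not set the value here. Nothing on record bears on the cause of this rise.

The step changes the ring nitrogen count and the point of attachment together, so their separate contributions remain unresolved; quinoxalin-6-yl and quinolin-5-yl at this place would separate them. Also open, as far as these compounds go, is whether a methoxy group or an amine on quinoxalin-5-yl would shift the number in either direction.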